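Swapping the carbonyl aryl group on compound 2

The source may report more compounds than this note shows. Statements on the series, on what has been measured and on what is new or still open speak of the compounds shown alone.

Compound 1 `CCCCc1ccc2[nH]c(-c3ccc(OC)cc3)c(/C=N/NC(=O)c3ccc(OC)cc3)c2c1`: 61 nM
Compound 2 `CCCCc1ccc2[nH]c(-c3ccc(C(F)(F)F)cc3)c(/C=N/NC(=O)c3ccc(OC)cc3)c2c1`: 284 nM
Compound 3 `CCCCc1ccc2[nH]c(-c3ccc(OC)cc3)c(/C=N/NC(=O)c3ccccc3OC)c2c1`: 21 nM

All three values come from a functional assay on MDA-MB-231 cells (Homo sapiens) for antiproliferative activity, with a stated time of 4 days; a higher number here means a weaker inhibitor, a lower number a stronger inhibitor. Among them, compound 2 has the highest number at 284 nM, which makes it the weakest inhibitor of the three. The step that leads to it is a 4.7-fold higher number from compound 1 to compound 2 (0.67 log units; beyond the scatter), with trifluoromethyl in place of methoxy on an aromatic carbon.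

Compound 4 `CCCCc1ccc2[nH]c(-c3ccc(C(F)(F)F)cc3)c(/C=N/NC(=O)c3cccnc3)c2c1` has not been measured. It keeps the trifluoromethyl group of compound 2 and alters the other end of the molecule: pyridin-3-yl in place of 4-methoxyphenyl on a carbonyl carbon. In short, pyridin-3-yl stands in place of 4-methoxyphenyl on a carbonyl carbon.

Among the measured compounds shown here, only one measured step touches this same place: a 2.9-fold lower number from compound 1 to compound 3 (0.46 log units; beyond the scatter), with 2-methoxyphenyl in place of 4-methoxyphenyl. It is a modest step, but it keeps a methoxyphenyl group and was measured with the methoxy group of compound 1 still in place of the trifluoromethyl. It is therefore only a rough guide to size. For the measured compounds named here, no measured compound carries pyridin-3-yl, so the data do not settle the direction.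

A step no larger than that modest one seems likely, with a slight lean towards a higher number in this assay. The estimated step is a 1.4-fold higher number from compound 2 to compound 4 (0.15 log units; within the scatter). Compound 4 is expected at 400 nM, with an estimated range from 120 nM to 1300 nM.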

Compound 4, half-maximal inhibitory concentration: 97 nM
For compound 4 the middle estimate is 4.1-fold (0.62 log units) above the measured one; measured number below the stated range.
By their numbers in this assay, from the lowest: compound 3; then compounds 1 and 4 (each within the scatter of the next); then compound 2.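

At this position, on the carbonyl carbon, a methoxyphenyl group turns out not to be needed for activity: with the trifluoromethyl group in place, pyridin-3-yl gives a 2.9-fold lower number from compound 2 to compound 4 (0.47 log units; beyond the scatter) in this assay. Among the compounds shown here, until now the only change here had kept a methoxyphenyl group and had been made with the methoxy group on the other aryl ring, as a 2.9-fold lower number from compound 1 to compound 3 (0.46 log units; beyond the scatter); this result extends the same direction to a ring that carries a nitrogen and no methoxy group, and to the trifluoromethyl series. No data on hand explain why the number falls with this swap.

The compounds shown leave open whether the lower number comes from the ring nitrogen or simply from losing the methoxy group, a question that a plain phenyl group at this position could help to separate, while pyridin-2-yl and pyridin-4-yl would show whether the place of that nitrogen in the ring matters. Going by these compounds, it also remains open whether pyridin-3-yl would lower the number to a similar extent on compound 1, where the other aryl ring keeps its methoxy group.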